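Replacing Bromo with Methylsulfanylphenyl on the Shared Core

The source may hold more compounds than are shown below. What is called first, only, known or untested is meant among the compounds shown, and "the series" means these compounds.

Compound 2 `O=C(CCc1cccc2c1B(O)OC2)Nc1cccc(Br)c1` gives the only number shown in an ADME assay on WI-38 cells (Homo sapiens) for cytotoxicity, read by MTT assay, with a stated time of 72 h (on this read-out higher numbers stand for weaker inhibition and lower numbers for stronger inhibition), 20000 nM. Compound 1 `CC(C)(C)NC(=O)CCc1cccc2c1B(O)OC2` is reported in this assay only as a limit, > 100000 nM. Among the measured compounds shown here, the step of an at least 5.0-fold lower number from compound 1 to compound 2 (0.69 log units; beyond the scatter) is the sole measured comparison available, and it concerns a different exchange, so it bears only loosely on what follows. Compound 3 `CSc1ccc(-c2cccc(NC(=O)CCc3cccc4c3B(O)OC4)c2)cc1` differs from compound 2 by 4-(methylsulfanyl)phenyl in place of bromo on an aromatic carbon. For the measured compounds named here, with no measured step on this exchange, only a modest move is expected in this assay, and compound 3 is estimated at 10000 nM, within 3000 nM to 40000 nM, which would mean an expected 2.0-fold lower number from compound 2 to compound 3 (0.30 log units; within the scatter).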

Compound 3, half-maximal inhibitory concentration: 3800 nM
Beside the measured number, compound 3's estimate is 2.6-fold (0.42 log units) above it; the range from low to high includes it.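

In this assay, the aromatic carbon that carries bromo in compound 2 accepts the much larger 4-(methylsulfanyl)phenyl, with a 5.3-fold lower number from compound 2 to compound 3 (0.72 log units; beyond the scatter). Among the compounds shown here, the earlier compounds varied only the group on the amide-type nitrogen, so this is the first measured change at this aromatic carbon, and the number falls again, beyond the scatter. Nothing measured here accounts for this step. The compounds shown leave open whether the added ring or its sulfur matters. A plain phenyl, a 4-methoxyphenyl or an amine on that carbon would help separate these.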